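From Branched Chain to Allyl: Expected Growth Inhibition

The compounds below may be only part of what the source reports. "The series", "measured", "known", "first", "only" and "open" are said of these compounds alone.

Of the compounds shown here, three sharing one core have been measured in a functional assay on the whole organism for inhibition, with Brassica rapa subsp. chinensis as the target, with a stated time of 3 days, tested at 100 ppm; on this read-out lower numbers stand for less inhibition of growth and higher numbers for more inhibition of growth at the one concentration tested. Compound 3 `CCC(C)NC(=O)/C=C/c1ccccc1` gives 56%, the highest of the three numbers. Compound 1 `CCCCCCNC(=O)/C=C/c1ccccc1` gives 55%, which lies within the scatter of compound 3. Going by the values given here, compound 2 `CC(C)NC(=O)/C=C/c1ccccc1` gives 39%, and the only single-point step measured, a number 17 percentage points higher from compound 2 to compound 3 (beyond the scatter), lies beyond the scatter.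

Compound 4 `C=CCNC(=O)/C=C/c1ccccc1` differs from compound 3 by allyl in place of sec-butyl on an amide-type nitrogen. Among the compounds with values here, no measured step covers this exchange directly. The step of a number 17 percentage points higher from compound 2 to compound 3 (beyond the scatter) shows that a methyl added on the chain attached to this nitrogen raised inhibition by a modest amount, and compound 4 gives up that branch and one carbon, so a drop of a comparable size is expected rather than a further gain. This rests on compound 2, whose group on the nitrogen likewise lacks that methyl and which gives 39%. Compound 4 is therefore expected to give 44%, between 28% and 60%. The expected step is a number 12 percentage points lower from compound 3 to compound 4 (beyond the scatter).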

Compound 4, percent growth inhibition at one concentration: 63%
Beside the measured number, compound 4's estimate is 19 percentage points below it; measured number above the stated range.
By their numbers in this assay, from the lowest: compound 2; then compounds 1, 3 and 4 (each within the scatter of the next).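

In this assay, allyl in place of sec-butyl on the amide-type nitrogen gives a number 7 percentage points higher from compound 3 to compound 4 (within the scatter), so this shorter, unbranched group with a double bond holds up as well as the branched one, and the methyl branch seen in the earlier step is not needed at this position. Allyl in place of isopropyl gives a number 24 percentage points higher from compound 2 to compound 4 (beyond the scatter), while vinyl in place of pentyl on a saturated chain carbon bound to an amide-type nitrogen gives a number 8 percentage points higher from compound 1 to compound 4 (within the scatter), so compound 2 remains the one clearly separated member of this set. Nothing measured here accounts for these results. From the compounds shown here alone, whether the double bond matters or only the chain size does stays open, and a saturated propyl group on the same nitrogen would test this. A propargyl or cyclopropylmethyl group would show how far this tolerance extends.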